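Trichlorophenyl analogue of the acrylamide: expected potency

The source may hold more compounds than are shown below. What is called first, only, known or untested is meant among the compounds shown, and "the series" means these compounds.

The series shares one core; compound 1 `CCC(=O)Nc1cccc(S(=O)(=O)N2CCC(NC(=O)c3n[nH]cc3NC(=O)c3c(Cl)cccc3Cl)CC2)c1`, compound 2 `CN(C)C/C=C/C(=O)Nc1cccc(S(=O)(=O)N2CCC(NC(=O)c3n[nH]cc3NC(=O)c3c(Cl)cccc3Cl)CC2)c1` and compound 3 `CCC(=O)Nc1cccc(CN2CCC(NC(=O)c3n[nH]cc3NC(=O)c3c(Cl)cccc3Cl)CC2)c1` have been measured, compound 4 `CN(C)C/C=C/C(=O)Nc1cccc(S(=O)(=O)N2CCC(NC(=O)c3n[nH]cc3NC(=O)c3c(Cl)cc(Cl)cc3Cl)CC2)c1` has not. For the measured compounds named here, in an assay on HEK293 cells for inhibition of cyclin-dependent kinase 14 (Homo sapiens), with a stated time of 4 h (a lower number here means a stronger inhibitor, a higher number a weaker inhibitor), compound 2 gives 50 nM, the only number so far. For compound 1 the result is a limit of the assay, > 1000 nM. For compound 3 the result is likewise a limit, > 1000 nM. Going by the values given here, the one step that can be sized, an at least 20-fold lower number from compound 1 to compound 2 (1.30 log units; beyond the scatter), is the exchange of the ethyl on a carbonyl carbon for the 3-(dimethylamino)prop-1-en-1-yl group; its size is bounded by the limit of > 1000 nM in this assay, at which 2 of the 3 values shown sit. Compound 4 differs from compound 2 by chloro in place of hydrogen on an aromatic carbon, that is 2,6-dichlorophenyl to 2,4,6-trichlorophenyl on the carbonyl. Among the compounds with values here, no measured step touches that ring, and the pair of compound 1 and compound 3 gives two limits only. The expectation for no change at the digits printed from compound 2 to compound 4 (within the scatter) is therefore no step beyond the scatter, in either direction. Compound 4 is estimated at 50 nM in this assay, with a range from 15 nM to 170 nM.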

Compound 4, half-maximal inhibitory concentration: >= 500 nM
Compound 4: no number, only a limit; the forecaster's own chance of this, stated with the estimate: 10%; at least 10-fold (1.00 log units) between middle value and limit.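

In this assay this position on the 2,6-dichlorophenyl ring does not tolerate every change: chloro in place of hydrogen, para to a large group and meta to two chloro groups, gives an at least 10-fold higher number from compound 2 to compound 4 (1.00 log units; beyond the scatter). For the compounds shown here, compound 4 gives >= 500 nM, which is a limit of the assay and not a number, so the step has a known minimum but no known size: the limit of >= 500 nM in this assay, at which 1 of the 4 values shown sits. No earlier step touched this ring, and the 3-(dimethylamino)prop-1-en-1-yl group is present in both compound 2 and compound 4, so keeping that group does not hold the value against this change.

The compounds shown leave open whether fluoro, methyl or methoxy in this same position would behave as chloro does, and so whether the step belongs to chlorine in particular or to any group placed here. Steps between compounds that both sit at limits cannot be read, so compound 1 and compound 3 add nothing on this question.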